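Shared-core series: aryl swap on the ring nitrogen, compound 3

A few compounds are considered here, and "the series" means these few. Any claim that something is new, unique, unknown or untested is made for them only; others in the source may bear on it.

Compound 1 `CCOc1ccc(-n2nncc2CN2C(=O)C3(C(C#N)=C(N)Oc4c(N)cc5nc6ccccc6nc5c43)c3ccccc32)cc1` — in an ADME assay on HUVEC cells (Homo sapiens) for antiproliferative activity, read by MTT assay, with a stated time of 48 h (a lower number here means a stronger inhibitor, a higher number a weaker inhibitor), compound 1 gives > 50000 nM, a limit of the assay and not a number.
Compound 2 `Cc1ccc(C)c(-n2nncc2CN2C(=O)C3(C(C#N)=C(N)Oc4c(N)cc5nc6ccccc6nc5c43)c3ccccc32)c1` — in this assay compound 2 gives > 50000 nM, likewise a limit and not a number.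

Among the measured compounds shown here, the single measured step, a step that the two limits leave unreadable from compound 1 to compound 2, cannot be read because of the limit of > 50000 nM in this assay, at which 2 of the 2 values shown sit. Compound 2 therefore stands at the limit of this assay, with no number of its own and no readable step to any other compound.

Compound 3 `N#CC1=C(N)Oc2c(N)cc3nc4ccccc4nc3c2C12C(=O)N(Cc1cnnn1-c1ccc(Cl)cc1Cl)c1ccccc12` is to be measured in this assay. Its change from compound 2: 2,4-dichlorophenyl in place of 2,5-dimethylphenyl on an aromatic nitrogen. For the measured compounds named here, the only measured step that bears on it, a step that the two limits leave unreadable from compound 1 to compound 2, is an aryl swap at the same nitrogen and gave no readable size; both aryl groups left the value at the limit (the limit of > 50000 nM in this assay, at which 2 of the 2 values shown sit). No direction beyond the scatter is therefore expected, and the step that the limit leaves unreadable from compound 2 to compound 3 is expected to be none beyond the scatter. Compound 3 is estimated at 80000 nM, with a range from 30000 nM to 300000 nM.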

Compound 3, half-maximal inhibitory concentration: > 50000 nM
Compound 3 ended at the assay's limit (the forecaster's own chance of this, stated with the estimate: 85%); the middle value is on the limit's open side.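

In this assay, among the compounds shown here, no step among compound 1, compound 2 and compound 3 can be read, because all three stand at a limit and not at a number: the limit of > 50000 nM in this assay, at which 3 of the 3 values shown sit.

The compounds shown leave open whether any aryl group on this ring nitrogen of the shared core gives a measurable value.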